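The source may report more compounds than this note shows. Statements on the series, on what has been measured and on what is new or still open speak of the compounds shown alone.

Working notes on the series. Within the data shown here, compound 1 `c1ccc2nc(COc3ccc(Cc4nnn[nH]4)cc3)ccc2c1` stands at the higher of the two numbers so far: in an assay on isolated protein for binding affinity to cysteinyl leukotriene receptor 1 (Cavia porcellus) (on this read-out higher numbers stand for weaker inhibition and lower numbers for stronger inhibition), compound 1 gives 275 nM, while compound 2 `c1cc(OCc2ccc3ccccc3n2)cc(OCc2nn[nH]n2)c1` gives 85 nM in this assay, a gap beyond the scatter. Compound 3 `c1ccc2nc(COc3ccc(CCc4nnn[nH]4)cc3)ccc2c1` differs from compound 1 only by (1H-tetrazol-5-yl)methyl in place of 1H-tetrazol-5-yl on a saturated chain carbon bound to an aromatic carbon. Among the measured compounds shown here, no measured pair shows this kind of change, so nothing fixes its size; the expected step in this assay from compound 1 to compound 3 is a 1.1-fold lower number from compound 1 to compound 3 (0.04 log units; within the scatter), within the scatter in either direction. Compound 3 is therefore estimated at 250 nM, with a range of 80 nM to 800 nM.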

Compound 3, inhibition constant: 160 nM
Compound 3: middle estimate off by 1.6-fold (0.19 log units), on the high side; low and high end bracket the measured number.
By their numbers in this assay, from the lowest: compounds 2, 3 and 1 (each within the scatter of the next, the first and the last beyond it).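

In this assay the change from 1H-tetrazol-5-yl to (1H-tetrazol-5-yl)methyl on a saturated chain carbon bound to an aromatic carbon gives a 1.7-fold lower number from compound 1 to compound 3 (0.24 log units; within the scatter) as the first step read at this place. On the core of compound 1, this one change therefore leaves the number within the scatter.

On these data alone, whether a longer chain or a carboxylic acid in place of the tetrazole keeps the number in the same range remains open. No evidence bears on what underlies this step.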